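The source may hold more compounds than are shown below. What is called first, only, known or untested is meant among the compounds shown, and "the series" means these compounds.

Compound 1 `O=C(O)c1csc([C@H]2CC[C@@H]3[C@@H](COc4ccccc4)[C@H](O)C[C@@H]3O2)n1` carries a phenoxy group on a saturated chain carbon bound to a saturated ring carbon of the shared core. In a functional assay on CHO cells for agonist activity at prostaglandin E2 receptor EP4 subtype (Homo sapiens), read by HTRF and cAMP accumulation, with a stated time of 30 min (a lower number here means that less compound is needed, a higher number that more compound is needed for the effect), compound 1 gives only > 10000 nM, which is a limit of the assay and not a number. Compound 1 therefore stands at the limit of > 10000 nM in this assay, at which 1 of the 2 values shown sits. Compound 2 `O=C(O)c1csc([C@H]2CC[C@@H]3[C@@H](/C=C/[C@@H](O)COc4ccccc4)[C@H](O)C[C@@H]3O2)n1` has a longer side chain that includes a double bond and a hydroxyl before the phenoxy group; in this assay compound 2 gives 33 nM. Compound 3 `O=C(O)c1csc([C@H]2CC[C@@H]3[C@@H](CCCOc4ccccc4)[C@H](O)C[C@@H]3O2)n1` has not yet been measured. The change from compound 1 to compound 3 is 2-phenoxyethyl in place of phenoxy on a saturated chain carbon bound to a saturated ring carbon. For the measured compounds named here, no step between two measured compounds covers this change, so only the values of compound 1 and compound 2 give a bearing, and compound 3 has a chain of similar length to compound 2 while lacking its hydroxyl and double bond. The author expects the step of an at least 10-fold lower number from compound 1 to compound 3 (1.00 log units; beyond the scatter) to be beyond the scatter, toward less compound being needed. For compound 3 the estimate in this assay is 1000 nM, expected to lie between 100 nM and 10000 nM.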

Compound 3, half-maximal effective concentration: > 10000 nM
Compound 3: a limit, no number; the forecaster's own chance of this, stated with the estimate: 20%; at least 10-fold (1.00 log units) between middle value and limit.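

In this assay compound 3 gives > 10000 nM, which is a limit of the assay and not a number. Compound 1 also stands at a limit, so no step can be read from compound 1 to compound 3. The compounds shown leave open whether 2-phenoxyethyl in place of phenoxy changes the concentration needed at all.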